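Two Fluorines in Place of One Chlorine

The source may report more compounds than this note shows. Statements on the series, on what has been measured and on what is new or still open speak of the compounds shown alone.

Of the compounds shown here, three have been measured in a functional assay on MCF7 cells (Homo sapiens) for cytotoxicity, read by trypan blue exclusion, with a stated time of 48 h; a lower number here means a stronger inhibitor, a higher number a weaker inhibitor. Compound 1 `O=C(COc1ccc(Cl)cc1)Nc1nc(-c2ccc(Br)cc2)cs1` gives 41400 nM. Compound 2 `O=C(COc1ccc(Cl)cc1)Nc1nc(-c2ccc(Cl)cc2)cs1` gives 44100 nM, and compound 3 `Cc1ccc(-c2csc(NC(=O)COc3ccccc3C(C)C)n2)cc1` gives 49000 nM. Within the data shown here, the only single-point step among them is a 1.1-fold higher number from compound 1 to compound 2 (0.03 log units; within the scatter), which changes nothing beyond the scatter. Compound 2 therefore sits in the middle of a tight cluster: its number lies close to that of compound 1 and close to that of compound 3, and both gaps are within the scatter of this assay.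

Compound 4 `O=C(COc1ccc(F)cc1F)Nc1nc(-c2ccc(Cl)cc2)cs1` is the next compound to be measured. It differs from compound 2 in one place: 2,4-difluorophenyl in place of 4-chlorophenyl on an oxygen on a saturated carbon. Among the measured compounds shown here, no measured pair touches this part of the molecule, since compound 3 differs from compound 2 in more than one place and the step from compound 1 to compound 2 concerns the other aromatic ring. The data thus give no direct guide for the size or direction of the change, and the three measured numbers lie so close together that a shift beyond the scatter is not the expectation here. For compound 4, the expected step is a 1.0-fold higher number from compound 2 to compound 4 (0.01 log units; within the scatter). Compound 4 is therefore estimated at 45000 nM, within a range from 20000 nM to 100000 nM.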

Compound 4, half-maximal inhibitory concentration: 25300 nM
For compound 4 the middle estimate is 1.8-fold (0.25 log units) above the measured one; measured number inside the range.
By their numbers in this assay, from the lowest: compounds 4, 1, 2 and 3 (each within the scatter of the next).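

In this assay the group on the oxygen on a saturated carbon can be exchanged with little consequence: 2,4-difluorophenyl in place of 4-chlorophenyl gives a 1.7-fold lower number from compound 2 to compound 4 (0.24 log units; within the scatter) and so stays inside the usual spread of repeated measurements. Among these compounds, the earlier single-point step concerned the other aromatic ring, so this is the first reading at this position, and it shows that two fluorines in place of one chlorine, with one more heavy atom in the group, bring no change beyond the scatter. Nothing available bears on why the number responds in this way.

With a single step at this position and each of the four compounds within the scatter of its neighbour in the order of their numbers, the compounds shown do not reveal whether any group here can move the number beyond the scatter. Going by these compounds, it stays open whether an amine or a carboxylic acid on this phenyl ring, or a longer chain in place of the ring, would give a step of a different size or direction.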